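Trimming a Methyl from the Side Chain of Compound 2

The compounds below may be only part of what the source reports. "The series", "measured", "known", "first", "only" and "open" are said of these compounds alone.

Measured so far:
compound 1 `NC(=O)CC[C@H](NC(=O)CN(c1ncnc2c1ncn2C1CCCCO1)C1CC1)C(=O)OCc1ccccc1`: 22.3%
compound 2 `C[C@@H](O)[C@H](NC(=O)CN(c1ncnc2c1ncn2C1CCCCO1)C1CC1)C(=O)OCc1ccccc1`: 10.9%

Both were tested in a functional assay on the whole organism (Tail, strain ICR) with Mus musculus as the target, in the tail flick test, with a stated time of 120 min, at a dose of 25 umol/kg by the oral route; on this read-out higher numbers stand for a stronger effect at the one dose given and lower numbers for a weaker effect. Among these two numbers compound 2 stands lowest; its nearest neighbour is compound 1, and the only measured step, a number 11.4 percentage points lower from compound 1 to compound 2 (beyond the scatter), separates them beyond the scatter.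

Compound 3 `O=C(CN(c1ncnc2c1ncn2C1CCCCO1)C1CC1)N[C@@H](CO)C(=O)OCc1ccccc1` differs from compound 2 in one place: hydrogen in place of methyl on a saturated chain carbon bound to an oxygen on a saturated carbon and a saturated chain carbon. Among the measured compounds shown here, no measured step bears on this change. For the measured compounds named here, the single known step, a number 11.4 percentage points lower from compound 1 to compound 2 (beyond the scatter), exchanged a different group, so it gives no guide to removing one carbon from the side chain, and nothing else is known about a change of this kind. Absent such guidance, the expected step in this assay is one within the scatter, a number 1.1 percentage points higher from compound 2 to compound 3 (within the scatter), which is close to no change. Compound 3 is therefore estimated to give 12%, expected to lie between 2% and 28%.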

Compound 3, a percentage reported as activity, at one dose (the size of the read-out at that dose, not a potency): 29.2%
Estimate against measurement, compound 3: 17.2 percentage points below; measured number outside the range, above it.
By their numbers in this assay, from the lowest: compound 2; then compounds 1 and 3 (each within the scatter of the next).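

The earlier compounds shown here showed only that exchanging one whole side chain for another could move the read-out. Here, in this assay, losing a single methyl from the 1-hydroxyethyl group to leave hydroxymethyl gives a number 18.3 percentage points higher from compound 2 to compound 3 (beyond the scatter), so the read-out responds to a change of one carbon at this place. The other comparison, a number 6.9 percentage points higher from compound 1 to compound 3 (within the scatter), cannot separate the hydroxymethyl side chain from the 2-carbamoylethyl one, and nothing available explains either step.

Still open, from the compounds shown here alone, is whether the hydroxy group matters at all, or whether a plain methyl side chain, an amine or a carboxylic acid in its place would read the same. Each number also comes from a single dose and time, so the ranking of these compounds at other doses remains unknown.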